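This account rests on a few compounds, and the source may have more. Where it says the series, first, only, none or still open, it means among the compounds named here.

Measured so far: compound 1 `CC(C)c1onc(-c2c(Cl)cccc2Cl)c1COc1ccc2c(c1)CN(c1cccc(C(=O)O)c1)C2=O` gives 1100 nM, compound 2 `CC(C)c1onc(-c2c(Cl)cccc2Cl)c1COc1ccc2c(ccn2Cc2cccc(C(=O)O)c2)c1` gives 210 nM, and compound 3 `CC(C)c1onc(-c2c(Cl)cccc2Cl)c1COc1ccc2c(ccn2Cc2ccc(C(=O)O)cc2)c1` gives 330 nM, all in an assay on CV-1 cells with Bile acid receptor (Homo sapiens) as the target, read by a luciferase reporter; on this read-out lower numbers stand for an effect already at smaller amounts and higher numbers for an effect only at larger amounts of compound.

Compound 3 stands second highest of the three numbers. Its nearest neighbour is compound 2, separated by a 1.6-fold higher number from compound 2 to compound 3 (0.20 log units; within the scatter), so the two cannot be told apart. Compound 1, with its different core, gives a clearly higher number than compound 3, but the two differ in more than one place and no single step can be read from that pair.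

Compound 4 `CC(C)c1onc(-c2c(Cl)cccc2Cl)c1COc1ccc2c(ccn2S(=O)(=O)c2cccc(C(=O)O)c2)c1` is made from compound 3 by a change on the aromatic nitrogen of the shared core: (3-carboxyphenyl)sulfonyl in place of 4-carboxybenzyl on an aromatic nitrogen. For the measured compounds named here, only one measured step touches this change. Going from compound 2 to compound 3 moved the carboxylic acid from 3-carboxyphenyl to 4-carboxyphenyl, and that move gave a 1.6-fold higher number from compound 2 to compound 3 (0.20 log units; within the scatter), within the scatter. Going by the values given here, compound 4 moves the acid back to the 3-position, which on that evidence should matter little, but it also swaps the saturated chain carbon for a sulfonyl group, and no measured pair tests this. The expected step is therefore a 1.2-fold higher number from compound 3 to compound 4 (0.08 log units; within the scatter), with a wide range, and compound 4 is estimated at 400 nM, between 120 nM and 1500 nM.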

Compound 4, half-maximal effective concentration: 1300 nM
Estimate against measurement, compound 4: 3.3-fold (0.51 log units) below; the measured number falls inside the stated range.
By their numbers in this assay, from the lowest: compounds 2 and 3 (each within the scatter of the next); then compounds 1 and 4 (each within the scatter of the next).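

The earlier compounds shown here showed only that moving the carboxylic acid around the ring of the benzyl group on the aromatic nitrogen left the number within the scatter, whereas the link joining that ring to the nitrogen proves to matter more in this assay. Putting (3-carboxyphenyl)sulfonyl in place of 3-carboxybenzyl keeps the acid at the same ring position and gives a 6.2-fold higher number from compound 2 to compound 4 (0.79 log units; beyond the scatter), while the swap from 4-carboxybenzyl gives a 3.9-fold higher number from compound 3 to compound 4 (0.60 log units; beyond the scatter), so both steps on this position lie beyond the scatter and point the same way. Nothing available here explains why the sulfonyl group goes with the higher number.

What the compounds shown leave open is whether a (4-carboxyphenyl)sulfonyl group would behave like the (3-carboxyphenyl)sulfonyl group, and whether a carbonyl link or a two-carbon chain on the aromatic nitrogen would stay with the lower numbers or move towards the higher one. Going by these compounds, all of them carry a carboxylic acid, so it also remains open how a tetrazole or a simple amide in its place would read.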